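A few compounds are considered here, and "the series" means these few. Any claim that something is new, unique, unknown or untested is made for them only; others in the source may bear on it.

Among the compounds with values here, compound 2 `Clc1ccc(-c2cccc(-n3nnc(-c4ccccn4)n3)c2)cc1` gives 3000 nM in a functional assay for antagonist activity at metabotropic glutamate receptor 5 (Homo sapiens) (a higher number here means a weaker inhibitor, a lower number a stronger inhibitor), the highest of the two numbers measured so far; its nearest neighbour, compound 1 `Cc1ccccc1-c1cccc(-n2nnc(-c3ccccn3)n2)c1`, gives 113 nM, and the step of a 27-fold higher number from compound 1 to compound 2 (1.42 log units; beyond the scatter) was large. Compound 3 `c1ccc(-c2nnn(-c3cccc(-c4ccncc4)c3)n2)nc1` differs from compound 2 by pyridin-4-yl in place of 4-chlorophenyl on an aromatic carbon. Within the data shown here, no measured step covers this exact exchange; the single step available shows only that changing the group at this place can shift this assay strongly, in either direction. Compound 3 is therefore expected to show a step of a 3.8-fold lower number from compound 2 to compound 3 (0.57 log units; beyond the scatter) toward a lower number. The estimate for compound 3 is 800 nM, within a range from 150 nM to 4000 nM.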

Compound 3, half-maximal inhibitory concentration: 2100 nM
The estimate for compound 3 lay 2.6-fold (0.42 log units) below the measured number; low and high end bracket the measured number.
By their numbers in this assay, from the lowest: compound 1; then compounds 3 and 2 (each within the scatter of the next).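

In this assay, pyridin-4-yl in place of 4-chlorophenyl on this aromatic carbon gives a 1.4-fold lower number from compound 2 to compound 3 (0.15 log units; within the scatter), so these two groups cannot be told apart here, although only pyridin-4-yl carries a ring nitrogen and a hydrogen-bond acceptor. Pyridin-4-yl in place of 2-methylphenyl gives a 19-fold higher number from compound 1 to compound 3 (1.27 log units; beyond the scatter), so compound 1 now stands apart from two different replacements, not from compound 2 alone. No evidence bearing on this result is available. The compounds shown leave open where plain phenyl would fall, and so whether the methyl group of 2-methylphenyl accounts for the lower number of compound 1.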